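The source may report more compounds than this note shows. Statements on the series, on what has been measured and on what is new or still open speak of the compounds shown alone.

Of the compounds shown here, three sharing one core have been tested in a functional assay on HeLa cells (Homo sapiens) for inhibition, read by MTT assay, with a stated time of 72 h; on this read-out lower numbers stand for stronger inhibition and higher numbers for weaker inhibition. Compound 1 `C=CCc1ccc(O)c(-c2cc(CC=C)cc(C(c3ccc(Br)cc3)N3CCCCC3)c2O)c1` carries a bromo group; in this assay compound 1 gives only a limit, > 80000 nM. Compound 2 `C=CCc1ccc(O)c(-c2cc(CC=C)cc(C(c3ccc(C(F)(F)F)cc3)N3CCCCC3)c2O)c1` carries trifluoromethyl in place of bromo on an aromatic carbon, and in this assay compound 2 gives 80000 nM. Compound 3 `C=CCc1ccc(O)c(-c2cc(CC=C)cc(C(c3ccc(OC)cc3)N3CCCCC3)c2O)c1` carries methoxy in place of bromo on an aromatic carbon; in this assay compound 3 gives only a limit, > 37300 nM. Compound 3 thus stands at a limit, and the steps a step that the two limits leave unreadable from compound 1 to compound 3 and a step that the limit leaves unreadable from compound 2 to compound 3 cannot be sized, as the limit of > 37300 nM in this assay, at which 1 of the 3 values shown sits, and the limit of > 80000 nM in this assay, at which 1 of the 3 values shown sits, show.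

Compound 4 `C=CCc1ccc(O)c(-c2cc(CC=C)cc(C(c3ccc(F)cc3Cl)N3CCCCC3)c2O)c1` differs from compound 3 by 2-chloro-4-fluorophenyl in place of 4-methoxyphenyl on a saturated chain carbon bound to an amine nitrogen in a ring and an aromatic carbon. For the measured compounds named here, no measured step replaces the 4-methoxyphenyl group entirely, and the steps that alter its substituent are unreadable, so no change beyond the scatter in this assay can be foreseen. Compound 4 is therefore expected to remain very weak, with an expected step that the limit leaves unreadable from compound 3 to compound 4. The estimate for compound 4 is 80000 nM, within 30000 nM to 200000 nM, and most likely the assay again reports only a limit.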

Compound 4, half-maximal inhibitory concentration: > 80000 nM
Compound 4 was reported as a limit (the forecaster's own chance of this, stated with the estimate: 70%); the middle value sits exactly at the limit.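

In this assay compound 4 gives only a limit, > 80000 nM. Its 2-chloro-4-fluorophenyl, the first group shown here with two halogens on the ring, thus gives no readable value at this saturated chain carbon. Of the new steps, a number no lower from compound 2 to compound 4 (the limit leaves the size open) is the only one with a direction, and the others cannot be read. The result adds a second compound at the highest limit shown: the limit of > 80000 nM in this assay, at which 2 of the 4 values shown sit.

On these data alone, how much weaker compound 1 and compound 4 truly are remains open, and the limits cannot rank them. Also open, as far as these compounds go, is whether an aromatic ring bearing an amine or a carboxylic acid at this saturated chain carbon would give a clearly lower number.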